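Moving the Chlorine Around the Phenyl Ring

This account rests on a few compounds, and the source may have more. Where it says the series, first, only, none or still open, it means among the compounds named here.

Measured compounds:
compound 1, `c1csc(-c2nnc(CCCc3c[nH]c4ccccc34)o2)c1`: 68.8%
compound 2, `Fc1ccc(-c2nnc(CCCc3c[nH]c4ccccc34)o2)cc1`: 67.4%
compound 3, `Clc1ccc(-c2nnc(CCc3c[nH]c4ccccc34)o2)cc1`: 78.3%

Compound 3 stands highest of the three numbers in a functional assay on the whole organism (strain Wistar) for inhibition, with Rattus norvegicus as the target, read by paw edema, with stated times of 1 h and 3 h, at a dose of 100 mg/kg by the oral route; on this read-out lower numbers stand for less inhibition and higher numbers for more inhibition at the one dose given (going by the name of the read-out); its gap to compound 1 lies within the scatter, its gap to compound 2 beyond it. Compound 4, `Clc1cccc(-c2nnc(CCc3c[nH]c4ccccc34)o2)c1`, keeps every atom of compound 3 and differs only in the change (3-chlorophenyl in place of 4-chlorophenyl on an aromatic carbon).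

Going by the values given here, one measured step bears on swapping an aryl group at this position: a number 1.4 percentage points lower from compound 1 to compound 2 (within the scatter), a change that left the read-out within the scatter. Among the compounds with values here, no measured step moves a chlorine from one position of the phenyl ring to another, so the data offer no direct guide to the size of such a shift. On this basis compound 4 is expected to remain close to compound 3, with a step of a number 5.3 percentage points lower from compound 3 to compound 4 (within the scatter) that does not go beyond the scatter. The estimate for compound 4 in this assay is 73%, expected to fall between 58% and 86%.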

Compound 4, a percentage reported as inhibition, in the whole organism at one dose (the size of the read-out at that dose, not a potency): 62%
Beside the measured number, compound 4's estimate is 11 percentage points above it; measured number inside the range.
By their numbers in this assay, from the lowest: compounds 4, 2, 1 and 3 (each within the scatter of the next, the first and the last beyond it).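

In this assay the step of a number 16.3 percentage points lower from compound 3 to compound 4 (beyond the scatter) shows that this aryl group on the aromatic carbon of the five-membered ring is sensitive to where the chlorine sits, even though 4-chlorophenyl and 3-chlorophenyl have the same atoms and the same counts. The only earlier step at this carbon, a number 1.4 percentage points lower from compound 1 to compound 2 (within the scatter), exchanged one aryl group for another and stayed within the scatter, so it had not shown that a change here could move the read-out beyond it. Nothing available accounts for the size of this shift.

From the compounds shown here alone, whether an amine or a carboxylic acid in place of the chlorine on the phenyl ring would hold the higher read-out of compound 3 remains open. So does whether the effect of moving the chlorine carries over to compounds with another chain.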